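Taking Off a Methyl: What to Expect for Compound 4

The compounds below may be only part of what the source reports. "The series", "measured", "known", "first", "only" and "open" are said of these compounds alone.

Of the compounds shown here, three have been measured in a functional assay, read by spectrophotometry, with a stated time of 5 min; on this read-out lower numbers stand for stronger inhibition and higher numbers for weaker inhibition. Compound 1 `O=c1[nH]c2ccccc2cc1/C=N/CCO` gives 467000 nM. Compound 3 `Cc1ccc2[nH]c(=O)c(/C=N/CCO)cc2c1` gives 1480000 nM, and compound 2 `Cc1ccc2[nH]c(=O)c(/C=N/c3ccc(S(N)(=O)=O)cc3)cc2c1` gives 258000 nM. Compound 2 and compound 3 share a methyl-bearing core, but the rest of each molecule differs; the difference between the two cores is not broken down here. Compound 1 and compound 3 differ in one place only: hydrogen in place of methyl on an aromatic carbon. That change produced a 3.2-fold lower number from compound 3 to compound 1 (0.50 log units; beyond the scatter).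

The unmeasured compound 4 `NS(=O)(=O)c1ccc(/N=C/c2cc3ccccc3[nH]c2=O)cc1` is reached from compound 2 by the same change: hydrogen in place of methyl on an aromatic carbon. Going by the values given here, only one measured example of this change exists, and it sits in a molecule whose remaining part differs from that of compound 2, so the expected size carries real uncertainty. Taking that single step as a guide, compound 4 is expected to come in at 100000 nM, with a likely range from 40000 nM to 260000 nM. For compound 4 this estimate means a 2.6-fold lower number from compound 2 to compound 4 (0.41 log units; beyond the scatter), close to the earlier step, expected because of a 3.2-fold lower number from compound 3 to compound 1 (0.50 log units; beyond the scatter).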

Compound 4, half-maximal inhibitory concentration: 169000 nM
Compound 4: middle estimate off by 1.7-fold (0.23 log units), on the low side; the measured number falls inside the stated range.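

Taking off the methyl gives a 1.5-fold lower number from compound 2 to compound 4 (0.18 log units; within the scatter), so on this core the change does not stand out from the usual variation between repeated measurements. Although only the earlier step lies beyond the scatter, the two steps cannot be told apart: the same change on two cores in this assay, a 3.2-fold lower number (0.50 log units; beyond the scatter) from compound 3 to compound 1 and a 1.5-fold lower number (0.18 log units; within the scatter) from compound 2 to compound 4, 2.1-fold (0.32 log units) apart, within the scatter of two such steps. This fits the change carrying over from one core to the other, but two pairs of compounds do not fix its size, do not show that the same size would hold on a further core, and do not explain what the methyl does.

As far as these compounds go, only hydrogen and methyl appear at this place on the aromatic carbon, so it remains open what a chlorine atom, a methoxy group or a carboxylic acid would do there. The rest of the molecule also takes only two forms among these compounds, so it is equally open whether the step would look the same with an amine or a longer chain in that part.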